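The source may hold more compounds than are shown below. What is called first, only, known or untested is meant among the compounds shown, and "the series" means these compounds.

Measured so far:
- compound 3 `CN(C)CCn1cnnc1-c1cc(Oc2ccc(NC(=O)N/N=C/c3c(O)ccc4ccccc34)cc2F)ccn1`: 3250 nM
- compound 1 `COc1ccc(OC)c(/C=N/NC(=O)Nc2ccc(Oc3ccnc(-c4nncn4CCN(C)C)c3)c(F)c2)c1`: "not determined" (no result reported)
- compound 2 `COc1ccc(/C=N/NC(=O)Nc2ccc(Oc3ccnc(-c4nncn4CCN(C)C)c3)c(F)c2)c(OC)c1OC`: "not determined" (no result reported)

Three compounds share one core and differ only in the group attached to the carbon that carries a double bond to nitrogen. In an ADME assay on WI-38 cells (Homo sapiens) for cytotoxicity, read by MTT assay, with a stated time of 72 h (a lower number here means a stronger inhibitor, a higher number a weaker inhibitor), compound 3 gives 3250 nM. Going by the values given here, that is the only number in this set: compound 1 and compound 2 were entered without a result, so compound 3 cannot be placed against anything measured, and no step between measured compounds can be given.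

Compound 4 `CN(C)CCn1cnnc1-c1cc(Oc2ccc(NC(=O)N/N=C/c3ccc(F)cc3Cl)cc2F)ccn1` is the next one to be tested. The change from compound 3 is 2-chloro-4-fluorophenyl in place of 2-hydroxynaphthalen-1-yl on a carbon with a double bond to nitrogen. Among the compounds with values here, with no measured step to lean on, the expectation can only rest on the single value of compound 3 and on the size of the change, which swaps one ring pair for a smaller single ring carrying two halogens. The step expected from compound 3 to compound 4 is a 1.5-fold higher number from compound 3 to compound 4 (0.19 log units; within the scatter), a move toward a slightly weaker effect that need not go beyond the usual scatter. For compound 4 the estimated result in this assay is 5000 nM, with a range from 1500 nM to 16000 nM.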

Compound 4, half-maximal inhibitory concentration: 2090 nM
The estimate for compound 4 lay 2.4-fold (0.38 log units) above the measured number; the range from low to high includes it.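

Going by these compounds alone, this is the first step that can be read at this position, the carbon with a double bond to nitrogen: in this assay, 2-chloro-4-fluorophenyl in place of 2-hydroxynaphthalen-1-yl gives a 1.6-fold lower number from compound 3 to compound 4 (0.19 log units; within the scatter). So a change from two aromatic rings to one, with the hydroxyl-bearing group giving way to one carrying two halogens, leaves the read-out within the usual scatter of this cytotoxicity measure, and the two compounds cannot be ranked. Nothing available here explains this result, so no cause can be named.

Steps to compound 1 and compound 2 cannot be read, so their methoxy-bearing rings add nothing to the comparison. Also open, as far as these compounds go, is how this position would respond to a ring carrying an amine or a carboxylic acid, or to a plain alkyl chain in place of the ring.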